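Working notes on an amide series in an antiproliferative assay

The source may report more compounds than this note shows. Statements on the series, on what has been measured and on what is new or still open speak of the compounds shown alone.

Measured so far:
compound 1 `CCc1ccc2nc(C(=O)Nc3c(F)cc(-c4cccc(F)c4)cc3F)c(C)c(O)c2c1`: 1.57%
compound 2 `Cc1c(C(=O)Nc2c(F)cc(-c3cccc(F)c3)cc2F)nc2ccc(F)cc2c1O`: 0%
compound 3 `CCc1ccc2nc(C(=O)Nc3c(F)cc(-c4cccc(F)c4)cc3F)c(C)c(C(=O)O)c2c1`: 2.45%

In a functional assay on A-375 cells (Homo sapiens) for antiproliferative activity, read by MTT assay, with a stated time of 24 h, tested at 0.14 ug/mL (a lower number here means a weaker effect, a higher number a stronger effect of the compound at the concentration tested), compound 1 gives 1.57%, compound 2 gives 0% and compound 3 gives 2.45%. The step of a number 1.6 percentage points lower from compound 1 to compound 2 (within the scatter) goes with fluoro in place of ethyl on an aromatic carbon. The step of a number 0.9 percentage points higher from compound 1 to compound 3 (within the scatter) goes with carboxy in place of hydroxy on an aromatic carbon, and this is also how the core of compound 3 differs from the core of compound 1. All three values lie within the scatter of one another, so no order among them can be read.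

Compound 4 `Cc1c(C(=O)Nc2c(F)cc(-c3cccc(F)c3)cc2F)nc2ccc(F)cc2c1C(=O)O` is not yet measured in this assay. From compound 3 it differs by fluoro in place of ethyl on an aromatic carbon, the same change as from compound 1 to compound 2, at a place described in the same words. The expected step is a number 1.5 percentage points lower from compound 3 to compound 4 (within the scatter), resting on the step of a number 1.6 percentage points lower from compound 1 to compound 2 (within the scatter), which stayed within the scatter. Compound 4 is therefore estimated to give about 1%, expected between 0% and 8%.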

Compound 4, a percentage reported as inhibition, at one concentration (the size of the read-out at that concentration, not a potency): 1.05%
Estimate against measurement, compound 4: 0.1 percentage points below, within the range that was stated.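

In this assay, the step of a number 1.4 percentage points lower from compound 3 to compound 4 (within the scatter) goes with fluoro in place of ethyl on an aromatic carbon, and it matches the same change on the other core: the same change on two cores in this assay, a number 1.6 percentage points lower (within the scatter) from compound 1 to compound 2 and a number 1.4 percentage points lower (within the scatter) from compound 3 to compound 4, 0.2 percentage points apart, within the scatter of two such steps. The step of a number 1.1 percentage points higher from compound 2 to compound 4 (within the scatter) goes with carboxy in place of hydroxy, and it also matches the earlier step: the same change on two cores in this assay, a number 0.9 percentage points higher (within the scatter) from compound 1 to compound 3 and a number 1.1 percentage points higher (within the scatter) from compound 2 to compound 4, 0.2 percentage points apart, within the scatter of two such steps. For the compounds shown here, since every step stays within the scatter, this agreement shows only that neither change moved the read-out beyond the scatter on these two cores, not that either change has a real effect that carries from one core to another.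

On these data alone, it remains open whether an amine or a longer chain in place of ethyl would give a read-out beyond the scatter. A single tested concentration also leaves open what effect any of the four compounds would have at another concentration.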